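Lengthening the Chain in a Flat Series

This account rests on a few compounds, and the source may have more. Where it says the series, first, only, none or still open, it means among the compounds named here.

In a functional assay, read by spectrophotometry, with a stated time of 6 min (on this read-out higher numbers stand for weaker inhibition and lower numbers for stronger inhibition), compound 1 (`CCCCCCOc1cc(OC)c(Br)cc1C(C)=O`) gives 35700000 nM, compound 2 (`CCOc1cc(OC)ccc1C(C)=O`) gives 37700000 nM and compound 3 (`CCCCOc1cc(OC)ccc1C(C)=O`) gives 36300000 nM. Compound 3 thus stands level with the other two, all within the scatter. The next structure, compound 4 (`CCCCCCOc1cc(OC)ccc1C(C)=O`), carries one change, (ethyl in place of hydrogen on a saturated chain carbon, four bonds along the chain from an oxygen on an aromatic ring), which places ethyl on a saturated chain carbon, four bonds along the chain from an oxygen on an aromatic ring. For the measured compounds named here, only one measured step is of the same kind, with ethyl two bonds along the chain: a 1.0-fold lower number from compound 2 to compound 3 (0.02 log units; within the scatter), which lies within the scatter. A similar outcome is therefore expected, with no shift beyond the scatter in this assay. The expected change is a 1.0-fold lower number from compound 3 to compound 4 (0.02 log units; within the scatter). Compound 4 is estimated at 35000000 nM, with an expected range of 20000000 nM to 60000000 nM.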

Compound 4, half-maximal inhibitory concentration: 42100000 nM
Estimate against measurement, compound 4: 1.2-fold (0.08 log units) below, within the range that was stated.
By their numbers in this assay, from the lowest: compounds 1, 3, 2 and 4 (each within the scatter of the next).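

In this assay, ethyl in place of hydrogen four bonds along the chain gives a 1.2-fold higher number from compound 3 to compound 4 (0.06 log units; within the scatter), so this position, like the one two bonds along, shows no shift beyond the scatter. Butyl in place of hydrogen two bonds along the chain gives a 1.1-fold higher number from compound 2 to compound 4 (0.05 log units; within the scatter), and hydrogen in place of bromo on an aromatic carbon gives a 1.2-fold higher number from compound 1 to compound 4 (0.07 log units; within the scatter), both also within the scatter. No outside evidence bears on this result. As far as these compounds go, whether an amine or a carboxylic acid in place of that ethyl, or a longer chain, would move the number beyond the scatter stays open.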